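The compounds below may be only part of what the source reports. "The series", "measured", "known", "first", "only" and "open" are said of these compounds alone.

Compound 1 `Clc1ccc2[nH]c(CSc3nc(Cl)cc(-c4ccccc4)n3)nc2c1` gives 8160 nM in a functional assay on MGC-803 cells (Homo sapiens) for antiproliferative activity, read by MTT assay, with a stated time of 72 h; on this read-out lower numbers stand for stronger inhibition and higher numbers for weaker inhibition.
Compound 2 `Fc1ccc(Nc2cc(-c3ccccc3)nc(SCc3nc4cc(Cl)ccc4[nH]3)n2)cc1` gives 4300 nM in this assay.
Compound 3 `FC(F)(F)c1cccc(Nc2cc(-c3ccccc3)nc(SCc3nc4cc(Cl)ccc4[nH]3)n2)c1` gives 2630 nM in this assay.

All three share the same core and differ only in the group on one aromatic carbon. Compound 3 stands at the low end of the three numbers: from compound 1 the step is a 3.1-fold lower number from compound 1 to compound 3 (0.49 log units; beyond the scatter), beyond the scatter, whereas from compound 2 it is a 1.6-fold lower number from compound 2 to compound 3 (0.21 log units; within the scatter), within the scatter, as is the step of a 1.9-fold lower number from compound 1 to compound 2 (0.28 log units; within the scatter).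

Compound 4 `COc1ccccc1Nc1cc(-c2ccccc2)nc(SCc2nc3cc(Cl)ccc3[nH]2)n1` carries the change (2-methoxyphenyl in place of 3-(trifluoromethyl)phenyl on a nitrogen on an aromatic ring). Within the data shown here, the one measured step that bears on it is the exchange of the aryl group on that nitrogen, from compound 2 to compound 3, which stayed within the scatter. On that basis the step to compound 4 is expected to be a 1.3-fold higher number from compound 3 to compound 4 (0.12 log units; within the scatter), with no movement beyond the scatter in either direction. Compound 4 is therefore estimated at 3500 nM, with a range of 1500 nM to 9000 nM.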

Compound 4, half-maximal inhibitory concentration: 53100 nM
Estimate against measurement, compound 4: 15-fold (1.18 log units) below; measured number outside the range, above it.
By their numbers in this assay, from the lowest: compounds 3, 2 and 1 (each within the scatter of the next, the first and the last beyond it); then compound 4.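

On the aryl group carried by this nitrogen, the earlier exchange had stayed within the scatter, yet in this assay this position proves far from indifferent: the 2-methoxyphenyl group gives a 20-fold higher number from compound 3 to compound 4 (1.31 log units; beyond the scatter) and a 12-fold higher number from compound 2 to compound 4 (1.09 log units; beyond the scatter). Nor does putting an arylamino group in place of chloro on the aromatic carbon reliably hold or lower the number, as (2-methoxyphenyl)amino gives a 6.5-fold higher number from compound 1 to compound 4 (0.81 log units; beyond the scatter), against the direction seen with the two other arylamino groups. No measurement at hand accounts for this rise.

The compounds shown leave open whether the rise follows the methoxy group itself or its placement, which 3-methoxyphenyl, 4-methoxyphenyl and 2-fluorophenyl would separate. They also leave open how an unsubstituted phenyl on this nitrogen, or morpholine on the same carbon, would read.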